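The source may report more compounds than this note shows. Statements on the series, on what has been measured and on what is new or still open speak of the compounds shown alone.

Measured compounds:
- compound 1 `C=CCc1ccc(OCc2cn(-c3ccc(C#N)cc3)nn2)c(O)c1` gave 37.5%
- compound 2 `C=CCc1ccc(OCc2cn(-c3ccc(OC)cc3)nn2)c(O)c1` gave 31.5%
- compound 3 `C=CCc1ccc(OCc2cn(-c3ccccc3CO)nn2)c(O)c1` gave 12.9%

In a functional assay on SK-N-SH cells (Homo sapiens) for inhibition, read by MTT assay, with a stated time of 72 h, tested at 30 uM (on this read-out higher numbers stand for more inhibition of growth at the one concentration tested and lower numbers for less inhibition of growth), compound 2 stands second highest of the three numbers. Its nearest neighbour is compound 1, the step being a number 6 percentage points lower from compound 1 to compound 2 (within the scatter); its furthest is compound 3, with a number 18.6 percentage points lower from compound 2 to compound 3 (beyond the scatter) and, for comparison, a number 24.6 percentage points lower from compound 1 to compound 3 (beyond the scatter).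

Compound 4 `C=CCc1ccc(OCc2cn(-c3ccc(C(=O)c4ccccc4)cc3)nn2)c(O)c1` differs from compound 2 by benzoyl in place of methoxy on an aromatic carbon. The step that bears most directly on this change is a number 6 percentage points lower from compound 1 to compound 2 (within the scatter), where one group at the same place gave way to another with little effect, whereas the larger drops came from exchanging the whole ring on the nitrogen. Because a number 6 percentage points lower from compound 1 to compound 2 (within the scatter) was small, compound 4 is expected to show a step of about a number 2.5 percentage points higher from compound 2 to compound 4 (within the scatter), none beyond the scatter. Compound 4 is therefore estimated at 34%, within a range from 14% to 54%.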

Compound 4, percent growth inhibition at one concentration: 41.9%
For compound 4 the middle estimate is 7.9 percentage points below the measured one; low and high end bracket the measured number.
By their numbers in this assay, from the lowest: compound 3; then compounds 2, 1 and 4 (each within the scatter of the next, the first and the last beyond it).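

This position, para to a large group, tolerates a group as large as benzoyl, which brings a further aromatic ring, with no loss of growth inhibition. Benzoyl in place of methoxy gives a number 10.4 percentage points higher from compound 2 to compound 4 (beyond the scatter), the only step at this position beyond the scatter, while benzoyl in place of cyano gives a number 4.4 percentage points higher from compound 1 to compound 4 (within the scatter). Nothing available explains these steps.

From the compounds shown here alone, it remains open how an amine or a carboxylic acid would fare at this position. Going by these compounds, whether a longer chain ending in a phenyl ring would match benzoyl also remains open.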